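Working notes: methyl in place of hydroxy

A few compounds are considered here, and "the series" means these few. Any claim that something is new, unique, unknown or untested is made for them only; others in the source may bear on it.

- compound 1 `COc1ccc2c(c1)CC[C@@H](O)/C2=C/c1cc(OC)c(OC)c(OC)c1`: 900 nM
- compound 2 `COc1ccc(/C=C2\c3cc(OC)c(OC)c(OC)c3CC[C@@H]2O)cc1N`: 160 nM
- compound 3 `COc1ccc(/C=C2\c3cc(OC)c(OC)c(OC)c3CC[C@@H]2O)cc1O`: 260 nM

In a functional assay on HT-29 cells (Homo sapiens) for inhibition, read by MTT assay (on this read-out lower numbers stand for stronger inhibition and higher numbers for weaker inhibition), compound 3 gives 260 nM, within the scatter of compound 2 and well under the number of compound 1. Compound 4 `COc1ccc(/C=C2\c3cc(OC)c(OC)c(OC)c3CC[C@@H]2O)cc1C` carries methyl in place of hydroxy on an aromatic carbon, ortho to a methoxy group (methyl in place of hydroxy on an aromatic carbon). For the measured compounds named here, the only measured step bearing on this change is a 1.6-fold higher number from compound 2 to compound 3 (0.21 log units; within the scatter), which replaces amino with hydroxy. Going by the values given here, no measured compound carries methyl there, so the evidence is thin. The expected result is a 1.2-fold higher number from compound 3 to compound 4 (0.09 log units; within the scatter), with no clear shift anticipated. For compound 4 the estimated value is 320 nM, with an expected range of 110 nM to 900 nM.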

Compound 4, half-maximal inhibitory concentration: 2560 nM
Estimate against measurement, compound 4: 8.0-fold (0.90 log units) below, and the stated range ends below it.
By their numbers in this assay, from the lowest: compounds 2 and 3 (each within the scatter of the next); then compound 1; then compound 4.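

At this place on the 3-hydroxy-4-methoxyphenyl ring, the change to methyl gives a 9.8-fold higher number from compound 3 to compound 4 (0.99 log units; beyond the scatter) in this assay, and the comparison with amino gives a 16-fold higher number from compound 2 to compound 4 (1.20 log units; beyond the scatter). So the position does not tolerate every small group, although the step between hydroxy and amino stayed within the scatter. Nothing available accounts for this loss.

The compounds shown leave open how a fluoro group, a chloro group or an ethyl chain would read at this place. From the compounds shown here alone, it also stays open whether methyl alone stands apart or hydroxy and amino are the exceptions.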